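Compound 3 to compound 4: furan-3-yl in place of phenyl

The source may hold more compounds than are shown below. What is called first, only, known or untested is meant among the compounds shown, and "the series" means these compounds.

In a functional assay on NCI-H460 cells (Homo sapiens) for antiproliferative activity, with a stated time of 72 h (on this read-out higher numbers stand for weaker inhibition and lower numbers for stronger inhibition), compound 1 `CCCCC#Cc1cc([C@@H]2O[C@H](CO)[C@@H](O)[C@H]2O)n2ncnc(N)c12` gives 1700 nM and compound 2 `Nc1ncnn2c([C@@H]3O[C@H](CO)[C@@H](O)[C@H]3O)cc(C#Cc3cccs3)c12` gives 26600 nM. Compound 3 `Nc1ncnn2c([C@@H]3O[C@H](CO)[C@@H](O)[C@H]3O)cc(-c3ccccc3)c12` gives > 100000 nM, which is a limit of the assay and not a number. Compound 3 thus stands at the limit of > 100000 nM in this assay, at which 1 of the 3 values shown sits.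

Compound 4 `Nc1ncnn2c([C@@H]3O[C@H](CO)[C@@H](O)[C@H]3O)cc(-c3ccoc3)c12` carries furan-3-yl in place of phenyl on an aromatic carbon.

Two measured steps end at compound 3: an at least 58-fold higher number from compound 1 to compound 3 (1.76 log units; beyond the scatter) and an at least 3.7-fold higher number from compound 2 to compound 3 (0.57 log units; beyond the scatter). Thiophen-2-yl in place of butyl gives a 16-fold higher number from compound 1 to compound 2 (1.19 log units; beyond the scatter). None of these steps exchanges one directly attached ring for another, so they bear on the new step only loosely. Since compound 3 offers only a limit, a return to a measurable number is possible but uncertain, and compound 4 may also remain at the limit.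

A modest move towards stronger inhibition is expected, estimated as an at least 2.5-fold lower number from compound 3 to compound 4 (0.39 log units; beyond the scatter). For compound 4 the expected value is 40000 nM, with an estimated range of 6000 nM to 100000 nM.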

Compound 4, half-maximal inhibitory concentration: 1500 nM
Compound 4: the middle estimate sits 27-fold (1.43 log units) above what was measured; measured number outside the range, below it.
By their numbers in this assay, from the lowest: compounds 4 and 1 (each within the scatter of the next); then compound 2. At a limit, above all of these: compound 3.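

In this assay a ring attached directly at this position need not mean a loss of inhibition, since furan-3-yl in place of phenyl gives an at least 66-fold lower number from compound 3 to compound 4 (1.82 log units; beyond the scatter) and phenyl alone accounts for the weak result. Compound 3 stands at a limit and not at a number, so that step has only a lower bound: (the limit of > 100000 nM in this assay, at which 1 of the 4 values shown sits). The triple bond is not required here either, with an 18-fold lower number from compound 2 to compound 4 (1.25 log units; beyond the scatter) and with a 1.1-fold lower number from compound 1 to compound 4 (0.05 log units; within the scatter) within the scatter, so compound 4 and compound 1 cannot be told apart.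

A single pair of rings cannot separate the ring oxygen of furan-3-yl from the smaller ring size. From the compounds shown here alone, whether thiophen-3-yl, a pyridine ring or a furan ring carrying an amine would behave like furan-3-yl stays open.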